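Methoxy to ethoxy at the limit of the assay

The source may hold more compounds than are shown below. What is called first, only, known or untested is meant among the compounds shown, and "the series" means these compounds.

Compound 1 `COc1ccccc1/C=C/c1nc(Nc2ccccc2Cl)c2ccccc2n1`: 16100 nM
Compound 2 `COc1ccc(/C=C/c2nc3ccccc3c(=O)[nH]2)cc1`: > 25000 nM (a limit, not a number)

From the compounds shown here alone, in a functional assay on HCT-116 cells (Homo sapiens) for antiproliferative activity, with a stated time of 72 h (a lower number here means a stronger inhibitor, a higher number a weaker inhibitor), compound 2 gives only a limit, > 25000 nM, so its true position on the scale is unknown. Compound 3 `CCOc1ccc(/C=C/c2nc3ccccc3c(=O)[nH]2)cc1` differs from compound 2 in one place: methyl in place of hydrogen on a saturated chain carbon bound to an oxygen on an aromatic ring, which turns methoxy into ethoxy. Within the data shown here, no measured pair shows the effect of this change, so no shift beyond the usual scatter is expected in this assay, in either direction. The expected size of the change is a step that the limit leaves unreadable from compound 2 to compound 3. The estimated value for compound 3 is 30000 nM, with an expected range of 13000 nM to 70000 nM.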

Compound 3, half-maximal inhibitory concentration: > 25000 nM
Compound 3: only a limit was reported; the forecaster's own chance of this, stated with the estimate: 70%; the middle value does not contradict the limit.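

No step can be read from compound 2 to compound 3, because each gives only a limit and not a number: the limit of > 25000 nM in this assay, at which 2 of the 3 values shown sit. The compounds shown leave open whether ethoxy in place of methoxy shifts the activity at all.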